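This account rests on a few compounds, and the source may have more. Where it says the series, first, only, none or still open, it means among the compounds named here.

Values so far in a functional assay on microsomes for inhibition, with a stated time of 1 h (a higher number here means a weaker inhibitor, a lower number a stronger inhibitor), are these:
- compound 1 `CCOC(=O)c1cnn(-c2nc(-c3ccccc3F)c(C#N)c(=O)n2C)c1N` gives 94 ug/mL
- compound 2 `CCOC(=O)c1cnn(-c2nc(-c3cccc(OC)c3OC)c(C#N)c(=O)n2C)c1N` gives 57 ug/mL
- compound 3 `CCOC(=O)c1cnn(-c2nc(-c3ccc(N(C)C)cc3)c(C#N)c(=O)n2C)c1N` gives 111 ug/mL

Compound 3 (111 ug/mL) lies within the scatter of both other compounds. The change to compound 4 `CCOC(=O)c1cnn(-c2nc(-c3cccc(O)c3O)c(C#N)c(=O)n2C)c1N` is 2,3-dihydroxyphenyl in place of 4-(dimethylamino)phenyl on an aromatic carbon and puts 2,3-dihydroxyphenyl in place of 4-(dimethylamino)phenyl on an aromatic carbon. Going by the values given here, two measured steps bear on this: a 1.2-fold higher number from compound 1 to compound 3 (0.07 log units; within the scatter) and a 1.9-fold higher number from compound 2 to compound 3 (0.29 log units; within the scatter) both stay within the scatter. Among the compounds with values here, no measured compound carries 2,3-dihydroxyphenyl. Compound 2 (57 ug/mL) carries 2,3-dimethoxyphenyl, so only a small move toward a lower number is expected, none beyond the scatter. The expected step in this assay is a 1.6-fold lower number from compound 3 to compound 4 (0.20 log units; within the scatter) and no larger. For compound 4 the estimated value is 70 ug/mL (expected range 25 ug/mL to 170 ug/mL).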

Compound 4, half-maximal inhibitory concentration: 49 ug/mL
Compound 4: middle estimate off by 1.4-fold (0.15 log units), on the high side; the range from low to high includes it.
By their numbers in this assay, from the lowest: compounds 4, 2, 1 and 3 (each within the scatter of the next, the first and the last beyond it).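

In this assay, this aromatic carbon ortho to a cyano group gives its first step beyond the scatter, though a modest one, with 2,3-dihydroxyphenyl in place of 4-(dimethylamino)phenyl (a 2.3-fold lower number from compound 3 to compound 4 (0.36 log units; beyond the scatter)). The same group stays within the scatter of the other two substituents (a 1.2-fold lower number from compound 2 to compound 4 (0.07 log units; within the scatter); a 1.9-fold lower number from compound 1 to compound 4 (0.28 log units; within the scatter)), so free hydroxyl groups are not distinguished from methoxy groups or from 2-fluorophenyl. No measurement on hand accounts for the step. 

Open, on these data alone, is whether both hydroxyl groups are needed. A single hydroxyl group, an amine or a carboxylic acid on this phenyl ring remains to be compared.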